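A Small Ring Replaces the Hydroxamic Acid Chain

The source may hold more compounds than are shown below. What is called first, only, known or untested is meant among the compounds shown, and "the series" means these compounds.

Of the compounds shown here, three sharing one core have been measured in a functional assay on KB cells (Homo sapiens) for inhibition, read by sulforhodamine B assay, with a stated time of 48 h; a higher number here means a weaker inhibitor of growth, a lower number a stronger inhibitor of growth. Compound 1 `COc1ccc2c(c1)NC(=O)CN2c1nc(Nc2cccc(C#N)c2)nc2ccccc12` gives 61.5 nM, compound 2 `COc1ccc2c(c1)NC(=O)CN2c1nc(NCc2ccncc2)nc2ccccc12` gives 7.5 nM, and compound 3 `COc1ccc2c(c1)NC(=O)CN2c1nc(COCCCC(=O)NO)nc2ccccc12` gives 307 nM, the highest of the three numbers. The change an 8.2-fold lower number from compound 1 to compound 2 (0.91 log units; beyond the scatter) shows how much the group on that aromatic carbon matters, while a 5.0-fold higher number from compound 1 to compound 3 (0.70 log units; beyond the scatter) and a 41-fold higher number from compound 2 to compound 3 (1.61 log units; beyond the scatter) show that swapping either amino group for the (3-(hydroxycarbamoyl)propoxy)methyl chain raises the number markedly.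

Compound 4 `COc1ccc2c(c1)NC(=O)CN2c1nc(N2CC(OC)C2)nc2ccccc12` reverses that direction: 3-methoxyazetidin-1-yl in place of (3-(hydroxycarbamoyl)propoxy)methyl on an aromatic carbon. The entering 3-methoxyazetidin-1-yl attaches through its ring nitrogen, like the two amino groups of compounds 1 and 2, so the steps from those compounds to compound 3 bear most directly, and a lower number than compound 3 is expected in this assay, probably of a size between those two steps. For compound 4 the estimate is 40 nM, with a range from 8 nM to 200 nM. This estimate means an expected step of a 7.7-fold lower number from compound 3 to compound 4 (0.89 log units; beyond the scatter).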

Compound 4, concentration for 50% growth inhibition: 8.26 nM
Compound 4: middle estimate off by 4.8-fold (0.69 log units), on the high side; low and high end bracket the measured number.
By their numbers in this assay, from the lowest: compounds 2 and 4 (each within the scatter of the next); then compound 1; then compound 3.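

In this assay, the step of a 37-fold lower number from compound 3 to compound 4 (1.57 log units; beyond the scatter) shows that the hydroxamic acid chain can leave this aromatic carbon, between two ring nitrogen atoms, and a much smaller group can take its place with a far lower number. The 3-methoxyazetidin-1-yl group, with its four-membered non-aromatic ring, also matches the ((pyridin-4-yl)methyl)amino group of compound 2, as a 1.1-fold higher number from compound 2 to compound 4 (0.04 log units; within the scatter) lies within the scatter. Against the (3-cyanophenyl)amino group it gives a 7.4-fold lower number from compound 1 to compound 4 (0.87 log units; beyond the scatter), so among these compounds an aromatic ring on this group is not needed for a low number.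

Nothing measured here explains these differences. On these data alone, whether the four-membered ring or its methoxy group matters more stays open, and an unsubstituted azetidine, a pyrrolidine or a morpholine on the same carbon would help to separate the two.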